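The compounds below may be only part of what the source reports. "The series", "measured", "known", "first", "only" and "open" are said of these compounds alone.

In a functional assay (mast cells) with Rattus norvegicus as the target (a lower number here means a stronger inhibitor, a higher number a weaker inhibitor), compound 1 (`Oc1nnc(-c2nc3ccccc3o2)o1`) gives 1200 nM and holds the higher of the two numbers, while compound 2 (`Oc1nnc(-c2nc3cc(Cl)ccc3o2)o1`) gives 350 nM and is the stronger inhibitor of the pair. Compound 3 (`Cc1ccc2nc(-c3nnc(O)o3)oc2c1`) has methyl in place of hydrogen on an aromatic carbon of compound 1 (methyl in place of hydrogen on an aromatic carbon). Going by the values given here, the only measured step that bears on this is chloro in place of hydrogen on an aromatic carbon (a 3.4-fold lower number from compound 1 to compound 2 (0.54 log units; beyond the scatter)), a modest step. Methyl is a different group, so a smaller step toward a lower number, about the size of the scatter, is expected (a 1.7-fold lower number from compound 1 to compound 3 (0.23 log units; within the scatter)). For compound 3 the estimate is 700 nM within an expected range (280 nM to 1700 nM).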

Compound 3, half-maximal inhibitory concentration: 5000 nM
Compound 3: middle estimate off by 7.1-fold (0.85 log units), on the low side; the measured number lies above the stated range.
By their numbers in this assay, from the lowest: compound 2; then compound 1; then compound 3.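

In this assay, methyl on this aromatic carbon brings a 4.2-fold higher number from compound 1 to compound 3 (0.62 log units; beyond the scatter), so a single added carbon here is enough to weaken the inhibitor. The chloro step on this ring, a 3.4-fold lower number from compound 1 to compound 2 (0.54 log units; beyond the scatter), ran the opposite way, so the direction of a change on this ring does not carry over from one group to another. Nothing available explains this loss. As far as these compounds go, whether fluoro, methoxy or an amine on this same carbon would also weaken the inhibitor remains open. So does whether ethyl or a longer chain would weaken it further.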